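This account rests on a few compounds, and the source may have more. Where it says the series, first, only, none or still open, it means among the compounds named here.

Three compounds share one core and differ only at its edge. In a physicochemical assay for lipophilicity, using the shake flask method, at pH 7.4 (a lower number here means a more polar compound, a higher number a more lipophilic compound), compound 1 `CN(C)[C@H]1CC[C@H](Nc2ncnc3sccc23)CC1` gives 0.1, compound 2 `CN(C)[C@H]1CC[C@H](Nc2ncnc3[nH]ccc23)CC1` gives -0.6, and compound 3 `CN(C)[C@H]1CC[C@H](Nc2ncnc3[nH]cc(C(F)(F)F)c23)CC1` gives 1.5. Compound 2 therefore stands lowest of the three, with compound 1 nearest and compound 3 furthest. Among the compounds with values here, the only single-site step measured so far, a number 2.10 log units higher from compound 2 to compound 3 (beyond the scatter), came with trifluoromethyl in place of hydrogen on an aromatic carbon. Compound 4 `CN(C)[C@H]1CC[C@H](Nc2ncnc3[nH]cc(C4CC4)c23)CC1` changes the same position: cyclopropyl in place of hydrogen on an aromatic carbon. That measured step bears on this one, but the entering group is not trifluoromethyl, so a rise beyond the scatter is expected, smaller than a number 2.10 log units higher from compound 2 to compound 3 (beyond the scatter). The expected step is a number 1.20 log units higher from compound 2 to compound 4 (beyond the scatter). For compound 4 the estimate in this assay is 0.6, between 0.1 and 1.1.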

Compound 4, distribution coefficient: 0.9
Compound 4: middle estimate off by 0.30 log units, on the low side; measured number inside the range.
By their numbers in this assay, from the lowest: compound 2; then compound 1; then compound 4; then compound 3.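

In this assay, this position now responds to a second group: cyclopropyl, a ring of carbon only, goes with a number 1.50 log units higher from compound 2 to compound 4 (beyond the scatter). So the rise seen with trifluoromethyl is not unique to that group, yet the two groups do not reach the same level: cyclopropyl in place of trifluoromethyl goes with a number 0.60 log units lower from compound 3 to compound 4 (beyond the scatter). Nothing measured here gives a cause for that gap. As far as these compounds go, whether an amine or a carboxylic acid here would move the number the other way, or a longer chain would carry it higher still, remains open.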